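Sulfur-bearing side chains: compound 3 to compound 4

The compounds below may be only part of what the source reports. "The series", "measured", "known", "first", "only" and "open" are said of these compounds alone.

In a functional assay on the whole organism with Rattus norvegicus as the target (on this read-out higher numbers stand for an effect only at larger amounts of compound and lower numbers for an effect already at smaller amounts), compound 3 (`CS(=O)(=O)CCCn1c(=N)sc2cc(OC(F)(F)F)ccc21`) gives 5 mg/kg and stands within the scatter of compound 2 (`CSCCCn1c(=N)sc2cc(OC(F)(F)F)ccc21`) at 4.2 mg/kg while compound 1 (`CS(=O)(=O)CCn1c(=N)sc2cc(OC(F)(F)F)ccc21`) at 1.8 mg/kg has the clearly lower number. Compound 4 (`CC[S+]([O-])CCn1c(=N)sc2cc(OC(F)(F)F)ccc21`) is not yet measured. Its difference from compound 3 is a group of 4 heavy atoms (2 carbon, 1 oxygen, 1 sulfur; no ring) in place of a group of 5 heavy atoms (2 carbon, 2 oxygen, 1 sulfur; no ring), on a saturated chain carbon, two bonds along the chain from an aromatic nitrogen and the group it gives up is (methylsulfonyl)methyl.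

Among the compounds with values here, three measured steps bear on this. The nearest is a 2.8-fold higher number from compound 1 to compound 3 (0.44 log units; beyond the scatter) which is modest and beyond the scatter and involves the same leaving group at the same carbon. The step of a 2.3-fold higher number from compound 1 to compound 2 (0.37 log units; beyond the scatter) is of similar size. The step of a 1.2-fold higher number from compound 2 to compound 3 (0.08 log units; within the scatter) stays within the scatter, so methylsulfonyl and methylsulfanyl on that chain are not told apart here.

Compound 4 carries its sulfur on that carbon as compound 1 does, which points toward the lower number of compound 1 at 1.8 mg/kg as a partial guide. Within the data shown here, no measured compound carries the entering group, so only part of that difference is assumed to carry over. In this assay the expected step is a 1.7-fold lower number from compound 3 to compound 4 (0.22 log units; within the scatter) toward a lower number, and it may not clear the scatter. For compound 4 the estimated value is 3 mg/kg with an expected range from 1.3 mg/kg to 7 mg/kg for now.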

Compound 4, dose for half-maximal effect: 1.2 mg/kg
Estimate against measurement, compound 4: 2.5-fold (0.40 log units) above; measured number outside the range, below it.
By their numbers in this assay, from the lowest: compounds 4 and 1 (each within the scatter of the next); then compounds 2 and 3 (each within the scatter of the next).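

In this assay, the entering group brings a clear fall against both compounds with the (methylsulfanyl)methyl or (methylsulfonyl)methyl group, with a 4.2-fold lower number from compound 3 to compound 4 (0.62 log units; beyond the scatter) and a 3.5-fold lower number from compound 2 to compound 4 (0.54 log units; beyond the scatter), so the low numbers are not confined to the methylsulfonyl group of compound 1. The step of a 1.5-fold lower number from compound 1 to compound 4 (0.18 log units; within the scatter) does not separate that pair, and the four compounds now form two sets: compounds 1 and 4 carry their sulfur on the saturated chain carbon two bonds along the chain from an aromatic nitrogen and have the lower numbers, compounds 2 and 3 have the higher numbers, and none of the four goes against this split. Nothing at hand gives a reason for the split.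

Compound 4 differs from compound 1 in both the oxygen count and the carbon count of its group, so the share of each in that step stays unresolved. Also open, on these data alone, is whether a methylsulfinyl or ethylsulfonyl group on that carbon would stay with compounds 1 and 4, and whether a sulfur-free group such as a carboxylic acid or an amine would do the same.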